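A few compounds are considered here, and "the series" means these few. Any claim that something is new, unique, unknown or untested is made for them only; others in the source may bear on it.

Measured so far:
compound 1 `CCCNc1cc(Oc2ccc(NC(=O)Nc3cccc(C(F)(F)F)c3)cc2)ncn1`: 32 nM
compound 2 `O=C(Nc1ccc(Oc2cc(O)ncn2)cc1)Nc1cccc(C(F)(F)F)c1`: 3200 nM

Among the compounds with values here, in an assay on isolated protein for inhibition of serine/threonine-protein kinase TNNI3K (Homo sapiens) (on this read-out higher numbers stand for weaker inhibition and lower numbers for stronger inhibition), compound 2 gives 3200 nM, the highest of the two numbers measured so far, and compound 1 gives 32 nM. Compound 3 `CC(C)CNc1cc(Oc2ccc(NC(=O)Nc3cccc(C(F)(F)F)c3)cc2)ncn1` has not yet been measured. The change from compound 2 to compound 3 is isobutylamino in place of hydroxy on an aromatic carbon. Within the data shown here, the only measured step that bears on it is a 100-fold higher number from compound 1 to compound 2 (2.00 log units; beyond the scatter), from propylamino to hydroxy. Isobutylamino resembles propylamino, so the expectation is that this large step is largely undone. In this assay compound 3 is therefore expected to give about 40 nM, within 15 nM to 130 nM, a step of an 80-fold lower number from compound 2 to compound 3 (1.90 log units; beyond the scatter).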

Compound 3, half-maximal inhibitory concentration: 50 nM
For compound 3 the middle estimate is 1.3-fold (0.10 log units) below the measured one, within the range that was stated.
By their numbers in this assay, from the lowest: compounds 1 and 3 (each within the scatter of the next); then compound 2.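

In this assay, the recovery from hydroxy on this aromatic carbon next to the ring nitrogen is not unique to propylamino: isobutylamino gives a 64-fold lower number from compound 2 to compound 3 (1.81 log units; beyond the scatter). The added methyl on the chain gives a 1.6-fold higher number from compound 1 to compound 3 (0.19 log units; within the scatter), so compound 1 and compound 3 stand level and this branch is tolerated. Nothing at hand accounts for the gap between hydroxy and the two amino chains. As far as these compounds go, whether the amine hydrogen matters remains open, and dimethylamino would address that. From the compounds shown here alone, how much size the position accepts also remains open, for a longer chain such as hexylamino or a cyclic amine such as morpholine.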